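Trifluoromethyl removal on the azo aryl and cytotoxicity

The compounds below may be only part of what the source reports. "The series", "measured", "known", "first", "only" and "open" are said of these compounds alone.

Of the compounds shown here, three from one series have been measured in an ADME assay on MT4 cells (Homo sapiens) for cytotoxicity, read by MTT assay, with a stated time of 96 h; a higher number here means that more compound is tolerated, a lower number that less compound is tolerated. Compound 3 `FC(F)(F)c1cccc(/N=N/c2ccc(NC[C@@H]3CCCN4CCCC[C@H]34)c3c2CCCC3)c1` gives 15000 nM, while compound 1 `c1ccc(/N=N/c2ccc(NC[C@@H]3CCCN4CCCC[C@H]34)c3c2CCCC3)cc1` gives 100000 nM. The change from compound 3 to compound 1 is hydrogen in place of trifluoromethyl on an aromatic carbon, and it gave a 6.7-fold higher number from compound 3 to compound 1 (0.82 log units; beyond the scatter). Compound 2 `Cc1c(/N=N/c2cccc(C(F)(F)F)c2)ccc(NC[C@@H]2CCCN3CCCC[C@H]23)c1C` gives 77000 nM in this assay; how the core of compound 2 differs from that of compound 3 is not broken down here. Compound 4 `Cc1c(/N=N/c2ccccc2)ccc(NC[C@@H]2CCCN3CCCC[C@H]23)c1C` is not yet measured; it differs from compound 2 by hydrogen in place of trifluoromethyl on an aromatic carbon, the same change as from compound 3 to compound 1. Resting on a 6.7-fold higher number from compound 3 to compound 1 (0.82 log units; beyond the scatter), the step from compound 2 to compound 4 is expected to be a 3.9-fold higher number from compound 2 to compound 4 (0.59 log units; beyond the scatter) in this assay. Compound 4 is estimated at 300000 nM, between 110000 nM and 800000 nM.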

Compound 4, half-maximal cytotoxic concentration: 31000 nM
Compound 4: the middle estimate sits 9.7-fold (0.99 log units) above what was measured; measured number outside the range, below it.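

Hydrogen in place of trifluoromethyl gave a 2.5-fold lower number from compound 2 to compound 4 (0.40 log units; beyond the scatter) in this assay. Set beside the earlier step, the same change does not carry from one core to the other, and its direction reverses: the same change on two cores in this assay, a 6.7-fold higher number (0.82 log units; beyond the scatter) from compound 3 to compound 1 and a 2.5-fold lower number (0.40 log units; beyond the scatter) from compound 2 to compound 4, 17-fold (1.22 log units) apart, beyond the scatter of two such steps

This shows that, for these two pairs, the outcome of the change depends on the core that carries it; it does not show which feature of the core matters, or how the change would behave on a further core. The compounds shown leave open whether a nitrile, a methoxy group or an amine on that aromatic carbon would also move the two cores in opposite directions. They also leave open which of the two steps would be the more typical in this series.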